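The source may report more compounds than this note shows. Statements on the series, on what has been measured and on what is new or still open speak of the compounds shown alone.

Measured in a physicochemical assay for solubility, read by LC-MS, in phosphate buffer, with a stated time of 24 h, at pH 6.8; a higher number here means a more soluble compound, a lower number a less soluble compound:
- compound 1 `C[C@@H](c1ccc(NC(=O)N2CC(c3cccnc3)C2)cc1)N1Cc2ccccc2C1=O`: 130000 nM
- compound 2 `C[C@H](NC(=O)C1CCOCC1)c1ccc(NC(=O)N2CC(c3ccc(N)nc3)C2)cc1`: 310000 nM
- compound 3 `C[C@@H](c1ccc(NC(=O)N2CC(c3cncc(N)c3)C2)cc1)N1Cc2ccccc2C1=O`: 35000 nM

Compound 3 holds the lowest number of these three in this assay. Compound 4 `C[C@H](NC(=O)C1CCOCC1)c1ccc(NC(=O)N2CC(c3cncc(N)c3)C2)cc1` differs from compound 3 in one place: a group of 9 heavy atoms (6 carbon, 1 nitrogen, 2 oxygen; one six-membered non-aromatic ring with 1 hetero atom) in place of a group of 10 heavy atoms (8 carbon, 1 nitrogen, 1 oxygen; one five-membered non-aromatic ring with 1 hetero atom, one six-membered aromatic ring of carbon only), on a saturated chain carbon bound to an aromatic carbon and a saturated chain carbon. Among the measured compounds shown here, no measured step covers this change. For the measured compounds named here, the only step available is a 3.7-fold lower number from compound 1 to compound 3 (0.57 log units; beyond the scatter), which is amino in place of hydrogen on an aromatic carbon. It is a modest step of a different kind, so it gives only a rough sense of how far one change has moved the numbers here. The closer guide is compound 2, which carries the same ((oxan-4-yl)carbonyl)amino group and gives 310000 nM, though it is a single compound and does not share every other feature of compound 4. On the value of compound 2, a higher number than that of compound 3 is expected, beyond the scatter. The expected change is a 5.1-fold higher number from compound 3 to compound 4 (0.71 log units; beyond the scatter). Compound 4 is estimated at 180000 nM, with an expected range of 60000 nM to 450000 nM.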

Compound 4, solubility: 440000 nM
For compound 4 the middle estimate is 2.4-fold (0.39 log units) below the measured one, and the stated range covers the measured number.
By their numbers in this assay, from the lowest: compound 3; then compound 1; then compounds 2 and 4 (each within the scatter of the next).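

In this assay, among the compounds shown here, replacing the group of 10 heavy atoms with ((oxan-4-yl)carbonyl)amino on this saturated chain carbon gives a 13-fold higher number from compound 3 to compound 4 (1.10 log units; beyond the scatter) and so puts a large measured step at a place no earlier pair had covered. With ((oxan-4-yl)carbonyl)amino in place, 5-aminopyridin-3-yl in place of 6-aminopyridin-3-yl on a saturated ring carbon gives a 1.4-fold higher number from compound 2 to compound 4 (0.15 log units; within the scatter) and does not separate the two compounds. Nothing measured here accounts for the size of the step at the chain carbon.

The compounds shown leave open whether the ring, the carbonyl or the amide hydrogen of the entering group carries the step, which an acetylamino group or a plain amine at that carbon could test. They also leave open how an unsubstituted pyridin-3-yl would read alongside ((oxan-4-yl)carbonyl)amino.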